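This account rests on a few compounds, and the source may have more. Where it says the series, first, only, none or still open, it means among the compounds named here.

Working notes on the series. Compound 2 `FC(F)(F)c1ccc2[nH]c(-c3ccccc3)nc2c1` gives in a functional assay on aorta (Rattus norvegicus, strain Wistar) for inhibition, with a stated time of 60 min (a lower number here means a smaller maximal response, a higher number a larger maximal response), a maximal response of 91.2%, the highest of the three numbers seen so far. Compound 1 `CCOc1ccccc1-c1nc2cc([N+](=O)[O-])ccc2[nH]1` lies nearest to it: in this assay compound 1 gives 84.8%, a gap within the scatter. Compound 3 `CC(C)Oc1ccccc1-c1nc2cc([N+](=O)[O-])ccc2[nH]1` lies furthest: in this assay compound 3 gives 80.7%, a gap beyond the scatter. Going by the values given here, the only one-place step measured so far, a number 4.1 percentage points lower from compound 1 to compound 3 (within the scatter), falls within the scatter.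

Compound 4 `CN(C)c1ccc(-c2nc3cc(C(F)(F)F)ccc3[nH]2)cc1` differs from compound 2 by dimethylamino in place of hydrogen on an aromatic carbon. Among the compounds with values here, no measured step touches an aromatic carbon of the ring that carries the change; the single step on record alters a saturated chain carbon bound to an oxygen and stays within the scatter. All three measured values, moreover, sit in a narrow band at the upper end of the scale. Nothing in the data therefore points to a step beyond the scatter for this assay in either direction, and the expected change a number 3.2 percentage points lower from compound 2 to compound 4 (within the scatter) is taken as flat. Compound 4 is estimated at 88%, with a range from 72% to 100%.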

Compound 4, largest response reached (Emax), in percent of the reference or control that the assay uses: 63.2%
Estimate against measurement, compound 4: 24.8 percentage points above; measured number outside the range, below it.
By their numbers in this assay, from the lowest: compound 4; then compounds 3, 1 and 2 (each within the scatter of the next, the first and the last beyond it).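

In this assay, going by these compounds alone, dimethylamino in place of hydrogen on an aromatic carbon gives a number 28 percentage points lower from compound 2 to compound 4 (beyond the scatter), the first one-place step on record that lies beyond the scatter. Within the data shown here, this place, an aromatic carbon para to a large group on a six-membered aromatic ring of carbon only, therefore responds to a change, whereas the only earlier step, a number 4.1 percentage points lower from compound 1 to compound 3 (within the scatter), alters a saturated chain carbon and stays within the scatter; with one step at each place and different cores, this sets no general rule. Nothing on record explains why dimethylamino has this effect on the maximal response.

A single substituent cannot show whether the drop belongs to dimethylamino itself or would follow any group on this carbon, and a methoxy group, a chlorine or a carboxylic acid at the same place would help separate the two. Also open, going by these compounds, are whether a longer chain on the nitrogen, as in diethylamino, or a ring amine such as morpholine would shift the response further, and whether dimethylamino gives a similar step on the core of compound 1.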